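A few compounds are considered here, and "the series" means these few. Any claim that something is new, unique, unknown or untested is made for them only; others in the source may bear on it.

In a functional assay on MDA-MB-231 cells (Homo sapiens) for inhibition, read by MTT assay, with a stated time of 72 h (on this read-out lower numbers stand for stronger inhibition and higher numbers for weaker inhibition), three compounds built on a shared core have been measured. Compound 1 `CC(C)=CCC[C@H](C)c1ccc(C)c2c1OCN(CC1CCNCC1)C2` gives 14900 nM, and compound 2 `CC(C)=CCC[C@H](C)c1ccc(C)c2c1OCN(CCCCCO)C2` gives 5400 nM; between them, a 2.8-fold lower number from compound 1 to compound 2 (0.44 log units; beyond the scatter). For compound 3 `CC(C)=CCC[C@H](C)c1ccc(C)c2c1OCN(CCCCC(=O)O)C2` the assay reports only a limit, > 50000 nM. This value is the limit of > 50000 nM in this assay, at which 1 of the 3 values shown sits. Compound 3 thus stands at the weak end of the set, since an at least 3.3-fold higher number from compound 1 to compound 3 (0.52 log units; beyond the scatter), and an at least 9.2-fold higher number from compound 2 to compound 3 (0.96 log units; beyond the scatter).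

Compound 4 `CCOC(CCN1COc2c([C@@H](C)CCC=C(C)C)ccc(C)c2C1)OCC` has not yet been measured. It differs from compound 3 in one place: diethoxymethyl in place of 2-carboxyethyl on a saturated chain carbon, two bonds along the chain from an amine nitrogen in a ring. Within the data shown here, the change removes the carboxy group, so the measured step that bears most on it is the one in which that group entered in place of hydroxymethyl, which raised the number by at least a modest amount and carried compound 3 up to the limit. Taking the carboxy group away again is expected to bring the number back toward the values of compound 1 and compound 2. The expected step is therefore an at least 5.0-fold lower number from compound 3 to compound 4 (0.69 log units; beyond the scatter), a decrease beyond the usual scatter. Compound 4 is estimated at 10000 nM, within a range from 3000 nM to 35000 nM.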

Compound 4, half-maximal inhibitory concentration: 11300 nM
For compound 4 the middle estimate is 1.1-fold (0.05 log units) below the measured one; low and high end bracket the measured number.
By their numbers in this assay, from the lowest: compound 2; then compounds 4 and 1 (each within the scatter of the next). At a limit, above all of these: compound 3.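

The reading of compound 3 is a limit and not a number: the limit of > 50000 nM in this assay, at which 1 of the 4 values shown sits.

At the place two bonds along the chain from an amine nitrogen in a ring, diethoxymethyl in place of 2-carboxyethyl gives an at least 4.4-fold lower number from compound 3 to compound 4 (0.64 log units; beyond the scatter), so this position accepts a group of 7 heavy atoms with no hydrogen-bond donor and still reads clear of the limit in this assay. The same group gives a 2.1-fold higher number from compound 2 to compound 4 (0.32 log units; beyond the scatter), a modest step, and a 1.3-fold lower number from compound 1 to compound 4 (0.12 log units; within the scatter), which leaves compound 4 level with compound 1, so a chain end need carry neither the hydroxyl of compound 2 nor the ring amine of compound 1 to stay in this range.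

The compounds shown leave open whether the carboxy group itself accounts for the weak reading of compound 3, and a methyl ester or a primary amide on the same chain would help to separate that group from its neighbours in the series. They also leave open how far chain length matters, since a simple amine or a longer chain ending in diethoxymethyl would each test this position with one feature changed.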